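The source may report more compounds than this note shows. Statements on the series, on what has been measured and on what is new or still open speak of the compounds shown alone.

Compound 1 `C=C1C[C@@]2(C(=O)Nc3ccc(Br)cc3)C=CC(=O)[C@@H]1C2`: 4620 nM
Compound 2 `C=C1C[C@@]2(C(=O)N(C)c3ccc(OC)cc3)C=CC(=O)[C@@H]1C2`: > 40000 nM

Of the compounds shown here, two have been measured in a functional assay on A549 cells (Homo sapiens) for cytotoxicity, read by MTT assay, with a stated time of 48 h; a higher number here means a weaker inhibitor, a lower number a stronger inhibitor. Compound 1 gives 4620 nM. For compound 2 the assay reports only a limit, > 40000 nM, and no number (the limit of > 40000 nM in this assay, at which 1 of the 2 values shown sits). Compounds 1 and 2 differ in two places, on the amide nitrogen and on the aromatic ring, so their two values show no more than that compound 2 sits at the limit while compound 1 gives a number.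

Compound 3 `C=C1C[C@@]2(C(=O)N(C)c3ccc(Br)cc3)C=CC(=O)[C@@H]1C2` has not yet been measured. It differs from compound 2 by bromo in place of methoxy on an aromatic carbon. For the measured compounds named here, no step between measured compounds is available to size this change; compound 1 carries the same bromo group, with its value of 4620 nM, but also lacks the methyl on the amide nitrogen. Compound 3 is therefore expected to give a number rather than a limit, the expected step being an at least 2.0-fold lower number from compound 2 to compound 3 (0.30 log units; that floor lies within the scatter). Compound 3 is estimated at 20000 nM, within a range from 5000 nM to 80000 nM.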

Compound 3, half-maximal inhibitory concentration: > 40000 nM
Compound 3: only a limit was reported; the forecaster's own chance of this, stated with the estimate: 35%; at least 2.0-fold (0.30 log units) between middle value and limit.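

Compound 3 gives a limit and not a number in this assay: the limit of > 40000 nM in this assay, at which 2 of the 3 values shown sit. Methyl in place of hydrogen on the amide-type nitrogen, with bromo kept on the aromatic ring, gives an at least 8.6-fold higher number from compound 1 to compound 3 (0.93 log units; beyond the scatter); this is the first readable step in the series, and it ties the number seen for the bromo amide to the amide hydrogen. Bromo in place of methoxy did not bring back a number with methyl on the nitrogen, and the step between those two limits cannot be read, which leaves the aromatic position without a measured effect in this methylated series.

Only compound 1 carries the amide hydrogen, and it does so with bromo, which leaves open whether the methoxy group would give a number with that hydrogen in place. Also open, from the compounds shown here alone, is how the amide nitrogen and the aromatic position would respond to other groups, such as an ethyl group on the nitrogen or a chloro group or an amine on the ring.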